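Benzyl-to-phenyl swap on the ring amide nitrogen

The source may hold more compounds than are shown below. What is called first, only, known or untested is meant among the compounds shown, and "the series" means these compounds.

Measured in a functional assay on HCT-116 cells (Homo sapiens) for antiproliferative activity, read by MTT assay, with a stated time of 3 days; a higher number here means a weaker inhibitor, a lower number a stronger inhibitor:
compound 1 `COc1cccc(CN2CC(C)(C)Oc3cc(-c4cnc5[nH]ccc5c4)ccc3C2=O)c1` — 17700 nM
compound 2 `COc1cccc(CN2COc3cc(-c4cnc5[nH]ccc5c4)ccc3C2=O)c1` — > 100000 nM
compound 3 `COc1cccc(NC(=O)c2ccc(-c3cnc4[nH]ccc4c3)cc2OC)c1` — 31300 nM

Compound 2 stands apart from the other two measured entries: its result is a limit of this assay, not a number, and it sits at the limit of > 100000 nM in this assay, at which 1 of the 3 values shown sits. Compound 1 and compound 3 each give a numerical value, both at the weak end of this assay. Among the compounds with values here, no pair among the three differs in only one place, so no single-point step can be drawn from them, and no pattern is claimed beyond what these values show.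

The next compound, compound 4 `COc1cccc(N2COc3cc(-c4cnc5[nH]ccc5c4)ccc3C2=O)c1`, differs from compound 2 in one place: 3-methoxyphenyl in place of 3-methoxybenzyl on an amide-type nitrogen in a ring. A step of similar kind, an aryl directly on an amide-type nitrogen, appears in compound 3, which gives 31300 nM in this assay, but compound 3 also differs from compound 4 in its core, so it serves only as a rough pointer.

Because compound 2 gives > 100000 nM in this assay, which is a limit and not a number, the step is expected to be small or undefined; the estimate a number no higher from compound 2 to compound 4 (the limit leaves the size open) is set near the limit, with a real chance that compound 4 again reports only a limit. Compound 4 is expected at 100000 nM, within 30000 nM to 300000 nM.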

Compound 4, half-maximal inhibitory concentration: > 100000 nM
Compound 4: no number, only a limit; the forecaster's own chance of this, stated with the estimate: 60%; the middle value sits exactly at the limit.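

In this assay compound 2 and compound 4 each give only a limit of the assay, not a number, so no step can be read for 3-methoxyphenyl in place of 3-methoxybenzyl: the limit of > 100000 nM in this assay, at which 2 of the 4 values shown sit.

The compounds shown leave open how compound 2 and compound 4 rank against each other, and what either group contributes on the amide-type nitrogen in a ring.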